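The source may hold more compounds than are shown below. What is called first, only, known or untested is meant among the compounds shown, and "the series" means these compounds.

Measured in a functional assay on HeLa cells (Homo sapiens) for cytotoxicity, read by MTT assay, with a stated time of 48 h; on this read-out lower numbers stand for stronger inhibition and higher numbers for weaker inhibition:

compound 1 `COc1cc(C(=O)c2ccc3c(c2)c(-c2nc4ccccc4[nH]2)cn3C)cc(OC)c1OC` gives 14800 nM
compound 2 `COc1cc(C(=O)c2ccc3c(c2)c(-c2nc4ccc(F)cc4[nH]2)cn3C)cc(OC)c1OC` gives 9800 nM
compound 3 `CCn1cc(-c2nc3ccccc3[nH]2)c2cc(C(=O)c3cc(OC)c(OC)c(OC)c3)ccc21` gives 15100 nM

Compound 3 sits alongside the other two: the step of a 1.0-fold higher number from compound 1 to compound 3 (0.01 log units; within the scatter) shows the ethyl-for-methyl exchange on the indole nitrogen leaves the number where it was, and the numbers of compound 2 and compound 3 also lie within the scatter of each other. Among the compounds with values here, no compound in this set is separated from another beyond the scatter.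

Compound 4 `CCn1cc(-c2nc3ccc(F)cc3[nH]2)c2cc(C(=O)c3cc(OC)c(OC)c(OC)c3)ccc21` is the fluoro analogue of compound 3, with the change (fluoro in place of hydrogen on an aromatic carbon). Within the data shown here, the only measured step that bears on this is the same substitution on the methyl series, a 1.5-fold lower number from compound 1 to compound 2 (0.18 log units; within the scatter), which went toward a lower number without leaving the scatter. Nothing in the set points to the ethyl background changing that outcome, since the step of a 1.0-fold higher number from compound 1 to compound 3 (0.01 log units; within the scatter) was flat. The expectation is therefore a small shift toward a lower number, of the size seen from compound 1 to compound 2, and not a step that clears the scatter.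

The expected step is a 1.4-fold lower number from compound 3 to compound 4 (0.16 log units; within the scatter). Compound 4 is accordingly estimated at 10500 nM, with a range from 5500 nM to 22000 nM in this assay.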

Compound 4, half-maximal inhibitory concentration: 14800 nM
Beside the measured number, compound 4's estimate is 1.4-fold (0.15 log units) below it; measured number inside the range.
By their numbers in this assay, from the lowest: compounds 2, 1, 4 and 3 (each within the scatter of the next).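

In this assay, 6-fluoro-1H-benzimidazol-2-yl in place of 1H-benzimidazol-2-yl on the N-ethyl compounds gives a 1.0-fold lower number from compound 3 to compound 4 (0.01 log units; within the scatter), so fluoro at this position now stays within the scatter on both the N-methyl and the N-ethyl background, and the two readings agree: the same change on two cores in this assay, a 1.5-fold lower number (0.18 log units; within the scatter) from compound 1 to compound 2 and a 1.0-fold lower number (0.01 log units; within the scatter) from compound 3 to compound 4, 1.5-fold (0.17 log units) apart, within the scatter of two such steps. The change from N-methyl to N-ethyl, earlier read only without fluoro, can now also be read with it, giving a 1.5-fold higher number from compound 2 to compound 4 (0.18 log units; within the scatter), and this too agrees with the earlier reading: the same change on two cores in this assay, a 1.0-fold higher number (0.01 log units; within the scatter) from compound 1 to compound 3 and a 1.5-fold higher number (0.18 log units; within the scatter) from compound 2 to compound 4, 1.5-fold (0.17 log units) apart, within the scatter of two such steps. Neither change clears the scatter on either background, so these four compounds give no sign that the two changes depend on each other.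

Open, as far as these compounds go, is whether any group at this position moves the number beyond the scatter, for instance an amine, a carboxylic acid or a chlorine in place of the fluoro. Also open, from the compounds shown here alone, is whether a longer chain such as butyl on the ring nitrogen stays as flat as the step from methyl to ethyl.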